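Swapping 4-cyanophenyl for 3,4,5-trimethoxyphenyl

This account rests on a few compounds, and the source may have more. Where it says the series, first, only, none or still open, it means among the compounds named here.

Three related compounds have been measured so far in a functional assay on HepG2 cells (Homo sapiens) for cytotoxicity, read by MTT assay, with a stated time of 24 h; a lower number here means a stronger inhibitor, a higher number a weaker inhibitor. Compound 1 (`CC(=O)Nc1ccc(S(=O)(=O)N2C/C(=C\c3ccccc3F)C(=O)/C(=C/c3ccccc3F)C2)cc1`) gives 5840 nM, compound 2 (`COc1cc(/C=C2\CN(S(=O)(=O)c3ccc(F)cc3)C/C(=C\c3ccccc3F)C2=O)cc(OC)c1OC`) gives 7940 nM, and compound 3 (`CC(=O)Nc1ccc(S(=O)(=O)N2C/C(=C\c3ccc(C#N)cc3)C(=O)/C(=C/c3ccccc3F)C2)cc1`) gives 4960 nM. All three numbers lie within the usual scatter of one another, so compound 3 does not stand apart from the other two.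

Compound 4 (`COc1cc(/C=C2\CN(S(=O)(=O)c3ccc(NC(C)=O)cc3)C/C(=C\c3ccccc3F)C2=O)cc(OC)c1OC`) differs from compound 3 in one place: 3,4,5-trimethoxyphenyl in place of 4-cyanophenyl on a double-bonded chain carbon bound to a double-bonded ring carbon. Within the data shown here, the one measured step at this kind of place is a 1.2-fold lower number from compound 1 to compound 3 (0.07 log units; within the scatter), and it stays within the scatter. Compound 2 already carries the 3,4,5-trimethoxyphenyl group, and its 7940 nM also falls within the scatter of the other two numbers. As far as these compounds go, no step beyond the scatter is therefore expected in this assay, and the direction stays open. The expected step is a 1.1-fold higher number from compound 3 to compound 4 (0.04 log units; within the scatter). For compound 4 the estimated value is 5500 nM, with an expected range from 2800 nM to 11000 nM.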

Compound 4, half-maximal inhibitory concentration: 4750 nM
Compound 4: the middle estimate sits 1.2-fold (0.06 log units) above what was measured; measured number inside the range.
By their numbers in this assay, from the lowest: compounds 4, 3, 1 and 2 (each within the scatter of the next).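

At the double-bonded chain carbon bound to a double-bonded ring carbon, 3,4,5-trimethoxyphenyl, with 12 heavy atoms against 8 for 4-cyanophenyl, gives a 1.0-fold lower number from compound 3 to compound 4 (0.02 log units; within the scatter) in this assay, and in place of 2-fluorophenyl it gives a 1.2-fold lower number from compound 1 to compound 4 (0.09 log units; within the scatter), so neither swap separates from the scatter. A second kind of change, acetamido in place of fluoro on an aromatic carbon, gives a 1.7-fold lower number from compound 2 to compound 4 (0.22 log units; within the scatter) and also stays within the scatter. Nothing available explains why these changes leave the numbers so close.

Every group shown at the double-bonded chain carbon is a substituted phenyl ring, so it remains open whether a carboxylic acid or an amine on that ring would shift the number beyond the scatter. As far as these compounds go, on the aromatic carbon that carries acetamido or fluoro, the effect of a longer chain also remains open.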